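Pyrazoline and oxadiazole series: paw edema inhibition notes

A few compounds are considered here, and "the series" means these few. Any claim that something is new, unique, unknown or untested is made for them only; others in the source may bear on it.

Measured compounds:
compound 1 `CN(C)c1ccc(C2CC(c3ccncc3)=NN2)cc1` gives 0%
compound 2 `COc1cc(-c2nc(-c3ccccn3)no2)ccc1O` gives 24%
compound 3 `COc1ccc(OC)c(C2CC(c3cccnc3)=NN2)c1` gives 15%

The three measured compounds were tested in a functional assay on the whole organism (strain Charles Foster albino) for inhibition, with Rattus norvegicus as the target, read by paw edema, with stated times of 30 min and 3 h, at a dose of 50 mg/kg by the oral route; a lower number here means less inhibition, a higher number more inhibition at the dose given (going by the name of the read-out). Compound 1 stands lowest of the three numbers; the nearest is compound 3, whose value lies higher by a gap beyond the scatter, and the furthest is compound 2, higher still, also beyond the scatter. None of these pairs differs in only one place, so the numbers show only where each compound stands and nothing about a single change.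

Compound 4 `CN(C)c1ccc(C2CC(c3ccncc3)=NN2c2ccccc2)cc1` differs from compound 1 in one place: phenyl in place of hydrogen on an amine nitrogen in a ring. Within the data shown here, no measured pair shows the effect of this change, so nothing gives its direction or size. Compound 1 sits at the floor of the read-out, so a step downward cannot appear. The step in this assay expected for compound 4 is small, upward if any, and likely within the scatter, giving a number 12 percentage points higher from compound 1 to compound 4 (beyond the scatter). Compound 4 is therefore estimated at 12%, with a range from 0% to 30%.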

Compound 4, a percentage reported as inhibition, in the whole organism at one dose (the size of the read-out at that dose, not a potency): 32%
Compound 4: middle estimate off by 20 percentage points, on the low side; measured number above the stated range.
By their numbers in this assay, from the lowest: compound 1; then compounds 3, 2 and 4 (each within the scatter of the next, the first and the last beyond it).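

In this assay, among these compounds, phenyl in place of hydrogen on the amine nitrogen in the ring gives a number 32 percentage points higher from compound 1 to compound 4 (beyond the scatter), a large step and the first change at a single place that the series can read. This position therefore accepts a six-membered aromatic ring of carbon only, and the read-out rises with it from the value of compound 1 at 0%, so the hydrogen on this nitrogen is not needed for the effect at the dose given. Nothing measured here explains the step.

On these data alone, whether the rise needs an aromatic ring at this nitrogen, or also comes with a methyl, acetyl or benzyl group there, stays open. Among the compounds shown here, also open is whether the step holds when the pyridin-4-yl group is replaced, since only this pair shows it.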